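The source may report more compounds than this note shows. Statements on the series, on what has been measured and on what is new or still open speak of the compounds shown alone.

Measured so far in an assay on HEK293 cells for displacement of a labelled ligand from Melanocortin receptor 4 (Homo sapiens); on this read-out lower numbers stand for stronger inhibition and higher numbers for weaker inhibition:
compound 1 `CC(C)C[C@H](N)c1cc(C(F)(F)F)ccc1N1CCN(C(=O)CC(C)C(=O)c2ccc(Cl)cc2)CC1` gives 1100 nM;
compound 2 `CC(C)C[C@H](N)c1cc(C(F)(F)F)ccc1N1CCN(C(=O)CCNC2CCCCC2)CC1` gives 4800 nM;
compound 3 `CC(C)C[C@H](N)c1cc(C(F)(F)F)ccc1N1CCN(C(=O)COc2cccc3ccccc23)CC1` gives 2600 nM.

Among the measured compounds shown here, compound 3 sits second highest of the three numbers: it lies within the scatter of compound 2 and differs from compound 1 by a 2.4-fold higher number from compound 1 to compound 3 (0.37 log units; beyond the scatter), the only step to it that clears the scatter. The step of a 1.8-fold lower number from compound 2 to compound 3 (0.27 log units; within the scatter) carries no usable signal.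

Compound 4 `Cc1cc(CC(C)C(=O)N2CCN(c3ccc(C(F)(F)F)cc3[C@@H](N)CC(C)C)CC2)ccc1Cl` changes the chain on the amide carbonyl of the shared core: 1-(4-chloro-3-methylbenzyl)ethyl in place of ((naphthalen-1-yl)oxy)methyl on a carbonyl carbon. The entering group is closer in kind to the chain of compound 1, a chlorinated phenyl on a methyl-branched chain, than to anything in compound 2 or compound 3. The step that bears on it is therefore a 2.4-fold higher number from compound 1 to compound 3 (0.37 log units; beyond the scatter), run in reverse: a chlorophenyl-bearing chain replaced the naphthalenyloxy chain gave the lowest number in the set. For the measured compounds named here, a modest move downward in this assay is expected for compound 4, roughly a 1.7-fold lower number from compound 3 to compound 4 (0.24 log units; within the scatter), though the branch and added methyl have no direct precedent here, so the range stays wide.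

Compound 4 is estimated at 1500 nM, between 500 nM and 5000 nM.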

Compound 4, inhibition constant: 71 nM
Estimate against measurement, compound 4: 21-fold (1.32 log units) above; measured number below the stated range.
By their numbers in this assay, from the lowest: compound 4; then compound 1; then compounds 3 and 2 (each within the scatter of the next).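

In this assay, among the compounds shown here, the chain on the carbonyl carbon of the shared core matters far more than the earlier steps suggested: 1-(4-chloro-3-methylbenzyl)ethyl in place of ((naphthalen-1-yl)oxy)methyl gives (a 37-fold lower number from compound 3 to compound 4 (1.56 log units; beyond the scatter)). The same entering group gives (a 68-fold lower number from compound 2 to compound 4 (1.83 log units; beyond the scatter)) against 2-(cyclohexylamino)ethyl and (a 15-fold lower number from compound 1 to compound 4 (1.19 log units; beyond the scatter)) against 2-((4-chlorophenyl)carbonyl)propyl, so compound 4 lies beyond the scatter of all three others. Compound 1 also carries a chlorinated phenyl ring, so that ring alone does not set the number of compound 4.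

The compounds shown do not separate the contributions of the ring methyl, the chlorine and the chain branch, and how an amine on that ring or a longer chain would read remains open. Nothing at hand explains the size of these steps.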